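Methyl on the Phenyl Ring: A Repeated Change

A few compounds are considered here, and "the series" means these few. Any claim that something is new, unique, unknown or untested is made for them only; others in the source may bear on it.

Measured compounds in a functional assay on MCF7 cells (Homo sapiens) for inhibition, read by colorimetric assay and MTT assay, with a stated time of 72 h; a higher number here means a weaker inhibitor, a lower number a stronger inhibitor:
- compound 1, `COc1ccc(C(=O)NNC(=S)Nc2csc(-c3ccccc3)c2)cc1`: 32000 nM
- compound 2, `COc1ccc(C(=O)NNC(=S)Nc2csc(-c3ccc(C)cc3)c2)cc1`: 5000 nM
- compound 3, `COc1cc(OC)cc(C(=O)NNC(=S)Nc2csc(-c3ccccc3)c2)c1`: 38000 nM

Compounds 1 and 2 differ in one place, (methyl in place of hydrogen on an aromatic carbon), and this gave a 6.4-fold lower number from compound 1 to compound 2 (0.81 log units; beyond the scatter). Compound 3 carries a different core; the difference between the core of compound 3 and the core of compound 1 is not broken down here. In this assay compound 3 and compound 1 give numbers that lie within the usual scatter of each other.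

Compound 4, `COc1cc(OC)cc(C(=O)NNC(=S)Nc2csc(-c3ccc(C)cc3)c2)c1`, has not yet been measured. It differs from compound 3 by methyl in place of hydrogen on an aromatic carbon, and the place of the change is described in the same words as for the change from compound 1 to compound 2, so it is the same change. Among the compounds with values here, with only one earlier example, the step is expected to be of similar size: a 5.4-fold lower number from compound 3 to compound 4 (0.73 log units; beyond the scatter), resting on the earlier change, which gave a 6.4-fold lower number from compound 1 to compound 2 (0.81 log units; beyond the scatter). Compound 4 is therefore estimated to give 7000 nM in this assay, with a range from 3000 nM to 20000 nM.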

Compound 4, half-maximal inhibitory concentration: 26000 nM
The estimate for compound 4 lay 3.7-fold (0.57 log units) below the measured number; the whole stated range lies below it.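

On the core of compound 3, the phenyl to 4-methylphenyl change did not repeat the size it had on the core of compound 1: in this assay it gave a 1.5-fold lower number from compound 3 to compound 4 (0.16 log units; within the scatter). The size of this step therefore depended on the core that carried it: the same change on two cores in this assay, a 6.4-fold lower number (0.81 log units; beyond the scatter) from compound 1 to compound 2 and a 1.5-fold lower number (0.16 log units; within the scatter) from compound 3 to compound 4, 4.4-fold (0.64 log units) apart, beyond the scatter of two such steps. This shows that, across these two cores, the earlier step was a poor guide to the size of the later one, but it does not show why they differ, and two cores cannot reveal which size is more typical of the series.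

The compounds shown leave open what the same methyl change would do on a third core, which could help show whether the large step on the core of compound 1 or the small step on the core of compound 3 is the exception. They also leave open whether a longer chain such as ethyl, or an amine, in the same place would depend on the core in the same way.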